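A few compounds are considered here, and "the series" means these few. Any claim that something is new, unique, unknown or untested is made for them only; others in the source may bear on it.

Working notes on the series.

Compound 1 `CCOC(=O)c1c(C)[nH]c(=O)c(C#N)c1-c1ccccc1` gives 38500 nM in a functional assay on HepG2 cells (Homo sapiens) for inhibition, read by MTT assay, with a stated time of 24 h; a higher number here means a weaker inhibitor, a lower number a stronger inhibitor. Compound 2 `CCOC(=O)c1c(C)[nH]c(=O)c(C#N)c1-c1ccc([N+](=O)[O-])cc1` gives 21700 nM in this assay, and compound 3 `CCOC(=O)c1c(C)[nH]c(=O)c(C#N)c1-c1ccc(C#N)cc1` gives 20200 nM. The numbers sit close together: a 1.8-fold lower number from compound 1 to compound 2 (0.25 log units; within the scatter), a 1.9-fold lower number from compound 1 to compound 3 (0.28 log units; within the scatter) and a 1.1-fold lower number from compound 2 to compound 3 (0.03 log units; within the scatter). Within the data shown here, compound 3 has the lowest of the three numbers, but no measured step separates it from compound 1 or compound 2 beyond the scatter, so no order among the three is claimed.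

Compound 4 `CCOC(=O)c1c(C)[nH]c(=O)c(C#N)c1-c1ccc(Br)cc1` has not yet been measured. It differs from compound 3 by bromo in place of cyano on an aromatic carbon. Among the measured compounds shown here, no measured step introduces a bromo group; the steps that bear on this one are the replacements at the same position, cyano in place of hydrogen and cyano in place of nitro, both within the scatter. Three substituents at this position all land within one band, so the expected step from compound 3 to compound 4 is a 1.3-fold higher number from compound 3 to compound 4 (0.11 log units; within the scatter), none beyond the scatter. Compound 4 is estimated at 26000 nM in this assay, with a range from 10000 nM to 65000 nM.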

Compound 4, half-maximal inhibitory concentration: 65500 nM
Beside the measured number, compound 4's estimate is 2.5-fold (0.40 log units) below it; the whole stated range lies below it.
By their numbers in this assay, from the lowest: compounds 3, 2, 1 and 4 (each within the scatter of the next, the first and the last beyond it).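

Among these compounds, at this position the substituent does matter: in this assay bromo gives the first steps beyond the scatter, a 3.2-fold higher number from compound 3 to compound 4 (0.51 log units; beyond the scatter) and a 3.0-fold higher number from compound 2 to compound 4 (0.48 log units; beyond the scatter) against the cyano and nitro compounds. Against hydrogen the same change gives a 1.7-fold higher number from compound 1 to compound 4 (0.23 log units; within the scatter) and stays within the scatter, so the separation holds only between bromo and the cyano and nitro groups, while compound 1 cannot be separated from any of the other three. Nothing available accounts for this separation.

Going by these compounds, whether the separation is particular to bromo or extends to chloro, fluoro, methoxy or an amine at this position stays open. On these data alone, all four compounds share the ethyl ester, so whether these steps would hold with a carboxylic acid in its place is also open.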